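The source may hold more compounds than are shown below. What is called first, only, known or untested is meant among the compounds shown, and "the series" means these compounds.

Measured compounds:
- compound 1, `O=C(Nc1cccc(-c2oc3cc(-c4ccc(F)cc4)ccc3c(=O)c2O)c1)c1ccc(F)cc1`: 14600 nM
- compound 2, `Cc1ccc(C(=O)Nc2cccc(-c3oc4cc(-c5ccc(F)cc5)ccc4c(=O)c3O)c2)cc1`: 12900 nM
- compound 3, `O=C(Nc1cccc(-c2oc3cc(-c4ccc(F)cc4)ccc3c(=O)c2O)c1)c1ccc(Cl)cc1`: 9140 nM

In a functional assay on GTL 16 cells for antiproliferative activity against GTL 16 cell line (Homo sapiens), read by CCK-8 assay, with a stated time of 72 h (on this read-out higher numbers stand for weaker inhibition and lower numbers for stronger inhibition), compound 1 gives 14600 nM, compound 2 gives 12900 nM and compound 3 gives 9140 nM. Among these three numbers compound 2 has the second highest, and all three lie within the scatter of one another, so no ordering between them can be claimed.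

Compound 4, `O=C(Nc1cccc(-c2oc3cc(-c4ccc(F)cc4)ccc3c(=O)c2O)c1)c1ccc(Br)cc1`, has not yet been measured. It differs from compound 2 in one place: bromo in place of methyl on an aromatic carbon.

For the measured compounds named here, two measured steps bear on this change, as each swaps one group at the same place. The step of a 1.6-fold lower number from compound 1 to compound 3 (0.20 log units; within the scatter) and the step of a 1.4-fold lower number from compound 2 to compound 3 (0.15 log units; within the scatter) both replace a small group with chloro, and both stay within the scatter. Bromo is the next halogen after chloro, so a change of similar size is expected in this assay for compound 4: a slightly lower number, if any, but nothing beyond the scatter.

The estimate for compound 4 is therefore 9000 nM, with a range of 4000 nM to 20000 nM, which means an expected step of a 1.4-fold lower number from compound 2 to compound 4 (0.16 log units; within the scatter).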

Compound 4, half-maximal inhibitory concentration: 25400 nM
Estimate against measurement, compound 4: 2.8-fold (0.45 log units) below; the whole stated range lies below it.
By their numbers in this assay, from the lowest: compounds 3, 2, 1 and 4 (each within the scatter of the next, the first and the last beyond it).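

In this assay, for the compounds shown here, the exchange of chloro for bromo gives a 2.8-fold higher number from compound 3 to compound 4 (0.44 log units; beyond the scatter) and is the first step at this position to pass the scatter, so swapping one halogen for the next can register here, if only modestly. The other two steps, a 2.0-fold higher number from compound 2 to compound 4 (0.29 log units; within the scatter) and a 1.7-fold higher number from compound 1 to compound 4 (0.24 log units; within the scatter) both stay within the scatter, so bromo cannot be told apart from methyl or fluoro at this position. Nothing available explains why chloro and bromo part here.

Going by these compounds alone, all four compounds carry only a single small group at this place on the 4-substituted phenyl ring, so how an amine, a carboxylic acid or a longer chain would read stays open. From the compounds shown here alone, whether the gap between chloro and bromo would hold up in other cell lines also stays open.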